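The source may hold more compounds than are shown below. What is called first, only, known or untested is meant among the compounds shown, and "the series" means these compounds.

Compound 1 `C[C@@H](NC1CCN(CCCc2c[nH]c3ccc(-n4cnnc4)cc23)CC1)c1ccccc1` gives 13 nM in an assay on CHO cells for agonist activity at 5-hydroxytryptamine receptor 1D (Homo sapiens), read by GTPgammaS binding (a lower number here means that less compound is needed, a higher number that more compound is needed for the effect), the highest of the three numbers in hand. Compound 3 `OC[C@H](NC1CCN(CCCc2c[nH]c3ccc(-n4cncn4)cc23)CC1)c1ccccc1` gives 7.4 nM, a value that sits within the scatter of that of compound 1. Compound 2 `c1ccc2c(c1)CCC2NCC1CCN(CCCc2c[nH]c3ccc(-n4cnnc4)cc23)CC1` gives 1.3 nM; the single-change step in hand is a 10-fold lower number from compound 1 to compound 2 (1.00 log units; beyond the scatter), and it alters the substituent on the saturated ring carbon, not the configuration of any centre.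

Compound 4 `C[C@H](NC1CCN(CCCc2c[nH]c3ccc(-n4cnnc4)cc23)CC1)c1ccccc1` carries the same atoms and bonds as compound 1 and differs only as drawn: the two compounds have the same atoms and bonds and differ only in configuration as drawn: 1 of 1 stereo elements differ; a stereocentre at a saturated chain carbon is drawn R in compound 1 and S in compound 4. Among the compounds with values here, no measured pair compares the two configurations at this centre, so none of the steps in hand bears on the change directly. The step from compound 1 to compound 2 shows only how far a change in this region of the molecule can move the number; it gives no direction for an inversion, and the data hold nothing on whether the drawn configuration of compound 1 is the more or the less potent one.

For compound 4 the expected value is 25 nM, with an estimated range from 4 nM to 160 nM. The step this estimate implies is a 1.9-fold higher number from compound 1 to compound 4 (0.28 log units; within the scatter), with wide uncertainty in either direction.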

Compound 4, half-maximal effective concentration: 12 nM
Compound 4: middle estimate off by 2.1-fold (0.32 log units), on the high side; the range from low to high includes it.
By their numbers in this assay, from the lowest: compound 2; then compounds 3, 4 and 1 (each within the scatter of the next).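

With compounds 1 and 4 the two configurations at the saturated chain carbon can now be compared directly, and inversion from R to S gives a 1.1-fold lower number from compound 1 to compound 4 (0.03 log units; within the scatter) in this assay, so this assay does not separate the two forms. The comparison isolates this single stereocentre: the fact that compounds 1 and 4 differ only in the configuration as drawn. The change from ((2,3-dihydro-1H-inden-1-yl)amino)methyl to (1-phenylethyl)amino also gives a 9.2-fold higher number from compound 2 to compound 4 (0.97 log units; beyond the scatter), so the gap between compound 2 and the (1-phenylethyl)amino series appears with either configuration at the chain carbon.

The compounds shown leave open whether inversion is equally silent in the hydroxyl-bearing compound 3, or when an ethyl group or a carboxylic acid replaces the methyl at this stereocentre. From the compounds shown here alone, compound 2 is drawn without a configuration at its 2,3-dihydro-1H-inden-1-yl group, so the contribution of that centre to its number also remains open.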